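Replacing the methyl group with nitro on the aryl amide

This account rests on a few compounds, and the source may have more. Where it says the series, first, only, none or still open, it means among the compounds named here.

Compound 1 `COc1cc2c(cc1OC)C(CC(=O)Nc1ccccc1)CC2`: 42.8%
Compound 2 `COc1cc2c(cc1OC)C(CC(=O)Nc1ccc(Cl)cc1)CC2`: 73.6%
Compound 3 `COc1cc2c(cc1OC)C(CC(=O)Nc1ccc(C)cc1)CC2`: 41.4%

Three amides sharing one core have been tested in a functional assay on the whole organism (strain Swiss Albino) for inhibition, with Mus musculus as the target, in the writhing test, with a stated time of 1 h, at a dose of 100 mg/kg by the oral route; on this read-out lower numbers stand for less inhibition and higher numbers for more inhibition at the one dose given (going by the name of the read-out). Compound 3 carries a methyl group on the aromatic ring of the amide and gives 41.4%, the lowest of the three numbers, though compound 1, with a bare ring, sits within the scatter of it (a number 1.4 percentage points lower from compound 1 to compound 3 (within the scatter)). Only compound 2, with chloro in the same place, stands clearly apart: a number 32.2 percentage points lower from compound 2 to compound 3 (beyond the scatter).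

Compound 4 `COc1cc2c(cc1OC)C(CC(=O)Nc1ccc([N+](=O)[O-])cc1)CC2` is not yet measured in this assay. It differs from compound 3 in one place: nitro in place of methyl on an aromatic carbon.

Going by the values given here, two measured steps bear on this change. Putting chloro where hydrogen was gave a number 30.8 percentage points higher from compound 1 to compound 2 (beyond the scatter), a large rise, while putting methyl there gave a number 1.4 percentage points lower from compound 1 to compound 3 (within the scatter), essentially no change. The site thus responds to at least one substituent, but nitro has not been tried here, so the direction of the step is uncertain. A moderate rise is expected for compound 4, a number 13.6 percentage points higher from compound 3 to compound 4 (beyond the scatter), with wide error. The value of compound 4 in this assay is estimated at 55%, between 30% and 80%.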

Compound 4, a percentage reported as inhibition, in the whole organism at one dose (the size of the read-out at that dose, not a potency): 55.8%
Compound 4: middle estimate off by 0.8 percentage points, on the low side, and the stated range covers the measured number.
By their numbers in this assay, from the lowest: compounds 3 and 1 (each within the scatter of the next); then compound 4; then compound 2.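

In this assay, nitro on this aromatic carbon produces a real gain over the unsubstituted ring (with a number 13 percentage points higher from compound 1 to compound 4 (beyond the scatter)) and over the methyl analogue (with a number 14.4 percentage points higher from compound 3 to compound 4 (beyond the scatter)), so chloro is no longer the only group shown to raise the number at this site. The gain stops short of the chloro level (with a number 17.8 percentage points lower from compound 2 to compound 4 (beyond the scatter)), which places nitro in an intermediate position and shows that the site separates one added group from another rather than simply rewarding any replacement of hydrogen; methyl in compound 3 is the case that goes against any such general rise. Nothing measured on these compounds or their groups accounts for this order.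

The compounds shown leave open how other groups would behave at this same place, such as an amine, a carboxylic acid, a methoxy group, or the halogens fluoro and bromo, and whether any of them would match or pass chloro. They also leave open whether the order seen here at a single dose would hold across a range of doses, since one percentage at one dose is not a measure of potency.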